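This account rests on a few compounds, and the source may have more. Where it says the series, first, only, none or still open, it means among the compounds named here.

Compound 1 `ClCc1ccccc1Cn1cnc2c(Cl)nc(Cl)nc21` gives 1540 nM in a functional assay on IGROV-1 cells (Homo sapiens) for cytotoxicity, read by sulforhodamine B assay, with a stated time of 48 h (on this read-out higher numbers stand for weaker inhibition of growth and lower numbers for stronger inhibition of growth), and this is the lowest of the two numbers that have been recorded. Going by the values given here, compound 2 `ClCc1cccc(Cn2cnc3nc(Cl)nc(Cl)c32)c1` gives 17000 nM in this assay, a number that lies well beyond the usual scatter from that of compound 1; the two structures differ in more than one place, so no single step connects them.

Compound 3 `Nc1nc(Cl)c2ncn(Cc3ccccc3CCl)c2n1` has not yet been measured. It departs from compound 1 by a single change, (amino in place of chloro on an aromatic carbon), on the shared core, at the carbon that sits between two ring nitrogen atoms. Among the compounds with values here, no measured pair shows this exchange, so its effect can only be guessed. Compound 3 is expected to retain growth inhibition in this assay, with a step of a 1.9-fold higher number from compound 1 to compound 3 (0.29 log units; within the scatter) from compound 1 that is expected to be modest and towards weaker inhibition. Compound 3 is therefore estimated at 3000 nM in this assay, within a range from 800 nM to 12000 nM.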

Compound 3, concentration for 50% growth inhibition: 6310 nM
Compound 3: middle estimate off by 2.1-fold (0.32 log units), on the low side; the measured number falls inside the stated range.
By their numbers in this assay, from the lowest: compound 1; then compound 3; then compound 2.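

Going by these compounds alone, replacing chloro with amino at the carbon between two ring nitrogen atoms is the first single change that can be read in this assay, and it gives a step towards weaker inhibition of growth (a 4.1-fold higher number from compound 1 to compound 3 (0.61 log units; beyond the scatter)). This position is therefore not indifferent to the exchange, yet inhibition of growth is weakened rather than lost, with compound 3 at 6310 nM in the same assay. No measurement shown accounts for the size or direction of this step.

As far as these compounds go, whether a methoxy group or a methylamino group at this carbon would give a number closer to that of chloro or of amino remains open. So does whether the same exchange would give a similar step on compound 2, whose chloromethyl group sits elsewhere on the benzene ring.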